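Replacing methoxy with methylsulfanyl in compound 2

The source may report more compounds than this note shows. Statements on the series, on what has been measured and on what is new or still open speak of the compounds shown alone.

Compound 1 `CCC1=C(O)c2c(oc(-c3ccc(CC)cc3)cc2=O)C(CC)(CC)C1=O` gives 0.07 uM
Compound 2 `CCC1=C(O)c2c(oc(-c3ccc(OC)cc3)cc2=O)C(CC)(CC)C1=O` gives 0.68 uM

In a functional assay on KBVIN cells (Homo sapiens) for antiproliferative activity, read by sulforhodamine B assay, with a stated time of 3 days (a higher number here means that more compound is needed for the effect, a lower number that less compound is needed), compound 2, at 0.68 uM, holds the higher of the two numbers. Compound 3 `CCC1=C(O)c2c(oc(-c3ccc(SC)cc3)cc2=O)C(CC)(CC)C1=O` differs from it in one place (methylsulfanyl in place of methoxy on an aromatic carbon), with methylsulfanyl in place of methoxy on an aromatic carbon. Among the measured compounds shown here, only one measured step bears on that carbon: a 9.7-fold higher number from compound 1 to compound 2 (0.99 log units; beyond the scatter), with methoxy in place of ethyl. For the measured compounds named here, no sulfur-bearing compound has been measured, so a modest move towards a lower number is expected rather than a full return. The expected change is a 2.7-fold lower number from compound 2 to compound 3 (0.43 log units; beyond the scatter) in this assay. For compound 3 the estimated value is 0.25 uM, within an expected range of 0.07 uM to 0.8 uM.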

Compound 3, concentration for half-maximal effect: 1.38 uM
For compound 3 the middle estimate is 5.5-fold (0.74 log units) below the measured one; measured number outside the range, above it.
By their numbers in this assay, from the lowest: compound 1; then compound 2; then compound 3.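

In this assay, going from 4-methoxyphenyl to 4-(methylsulfanyl)phenyl brings no recovery towards the ethyl compound, but instead a 2.0-fold higher number from compound 2 to compound 3 (0.31 log units; beyond the scatter). Measured against ethyl directly, the sulfur-bearing group gives a 20-fold higher number from compound 1 to compound 3 (1.29 log units; beyond the scatter), so compound 1 keeps the lowest number of the three, and both groups with a heteroatom on this aromatic carbon stand above it. No measurement at hand accounts for this order. Open, as far as these compounds go, is whether a longer chain such as propyl, or an amine, on this carbon would match compound 1 or go lower.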